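Urea substituent swap on a shared anilinopyrazine core

The compounds below may be only part of what the source reports. "The series", "measured", "known", "first", "only" and "open" are said of these compounds alone.

Compound 1 `COc1ccccc1NC(=O)Nc1cccc(CNc2nccnc2Cl)c1`: 10400 nM
Compound 2 `CN(C)c1ccc(NC(=O)Nc2cccc(CNc3nccnc3Cl)c2)cc1`: 20200 nM
Compound 3 `O=C(Nc1cccc(CNc2nccnc2Cl)c1)NC1CCCCC1`: > 40000 nM

In a functional assay on T-24 cells (Homo sapiens) for antiproliferative activity, read by MTT assay, with a stated time of 48 h (on this read-out lower numbers stand for stronger inhibition and higher numbers for weaker inhibition), compound 1 gives the lowest of the two full numbers, with compound 2 sitting a 1.9-fold higher number from compound 1 to compound 2 (0.29 log units; within the scatter). Compound 3 reaches only a limit, (the limit of > 40000 nM in this assay, at which 1 of the 3 values shown sits), so the step of an at least 3.8-fold higher number from compound 1 to compound 3 (0.58 log units; beyond the scatter) is at least modest. Compound 4 `O=C(Nc1cccc(CNc2nccnc2Cl)c1)Nc1ccc(Cl)c(Cl)c1` differs from compound 1 by 3,4-dichlorophenyl in place of 2-methoxyphenyl on an amide-type nitrogen. Both measured steps leave the urea on a different group and both go toward higher numbers, but neither carries the entering group here, so they bear only loosely on this step. An estimated step of a 1.3-fold lower number from compound 1 to compound 4 (0.11 log units; within the scatter) is expected, within the scatter. Compound 4 is therefore expected near 8000 nM, in the range 2500 nM to 25000 nM.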

Compound 4, half-maximal inhibitory concentration: 5210 nM
The estimate for compound 4 lay 1.5-fold (0.19 log units) above the measured number, and the stated range covers the measured number.
By their numbers in this assay, from the lowest: compounds 4, 1 and 2 (each within the scatter of the next, the first and the last beyond it). At a limit, above all of these: compound 3.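

The 3,4-dichlorophenyl group on the amide-type nitrogen stays level with 2-methoxyphenyl (a 2.0-fold lower number from compound 1 to compound 4 (0.30 log units; within the scatter)), so an aryl group with no hydrogen-bond acceptor matches one that carries an acceptor. Among the compounds shown here, it also gives the first step beyond the scatter between two aryl ureas (a 3.9-fold lower number from compound 2 to compound 4 (0.59 log units; beyond the scatter)), which compounds 1 and 2 did not show. Compound 3 gives only a limit, so the step from cyclohexyl (an at least 7.6-fold lower number from compound 3 to compound 4 (0.88 log units; beyond the scatter)) is a floor: the limit of > 40000 nM in this assay, at which 1 of the 4 values shown sits.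

The compounds shown leave open whether a single chlorine, a nitrile or a carboxylic acid on the phenyl ring would hold this level. On these data alone, whether an open-chain butyl group behaves like cyclohexyl also stays open.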